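A few compounds are considered here, and "the series" means these few. Any claim that something is new, unique, unknown or untested is made for them only; others in the source may bear on it.

Two measured compounds share one core and differ at a single aromatic carbon: compound 1 `COc1ccc2c(c1)OC(N)=C(C#N)C2c1cccc(Br)c1` and compound 2 `COc1ccc2c(c1)OC(N)=C(C#N)C2c1cccc(Cl)c1`. In a functional assay on T47D cells (Homo sapiens) for activation (a lower number here means that less compound is needed, a higher number that more compound is needed for the effect), compound 1 gives 52000000 nM, and compound 2 gives 80000000 nM. For the measured compounds named here, the one step available, a 1.5-fold higher number from compound 1 to compound 2 (0.19 log units; within the scatter), lies within the scatter. Going by the values given here, compound 2 thus stands within the scatter of compound 1, the only other measured compound, and no order between the two can be read.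

Compound 3 `COc1cccc(C2C(C#N)=C(N)Oc3cc(OC)ccc32)c1` arises from compound 2 by methoxy in place of chloro on an aromatic carbon. Among the compounds with values here, no measured step exchanges a halogen for a methoxy group on this ring; the only step at hand, a 1.5-fold higher number from compound 1 to compound 2 (0.19 log units; within the scatter), replaced one halogen with another and stayed within the scatter. On that basis no step beyond the scatter is expected in this assay, so the expected step is no change at the digits printed from compound 2 to compound 3 (within the scatter). Compound 3 is estimated at 80000000 nM in this assay, with a range from 25000000 nM to 250000000 nM.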

Compound 3, half-maximal effective concentration: 52000000 nM
For compound 3 the middle estimate is 1.5-fold (0.19 log units) above the measured one, within the range that was stated.
By their numbers in this assay, from the lowest: compounds 1, 3 and 2 (each within the scatter of the next).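

In this assay the exchange of a halogen for methoxy on this aromatic carbon gives a 1.5-fold lower number from compound 2 to compound 3 (0.19 log units; within the scatter) and, starting from the bromo compound, no change at the digits printed from compound 1 to compound 3 (within the scatter). The place meta to a large group thus holds chloro, bromo or methoxy with all three compounds within the scatter of one another, so the earlier halogen-for-halogen result now extends to a non-halogen group in these compounds. No supporting measurement is available that bears on this result.

From the compounds shown here alone, whether an amine, a carboxylic acid or a longer chain such as butoxy at this place would give a step beyond the scatter remains open. The three groups shown also leave open whether any change at this carbon can shift the number in this series.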